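Working notes on compounds 1 to 4 in one cytotoxicity read-out

The source may report more compounds than this note shows. Statements on the series, on what has been measured and on what is new or still open speak of the compounds shown alone.

Measured in a functional assay on CCRF-CEM cells (Homo sapiens) for cytotoxicity, read by cell counting, with a stated time of 3 days; on this read-out higher numbers stand for weaker inhibition and lower numbers for stronger inhibition:
compound 1 `C=C(Br)C(=O)Nc1cccc(/C=C2\SC(=O)N(Cc3ccc(C)cc3)C2=O)c1` gives 1200 nM
compound 2 `C=C(Br)C(=O)Nc1cccc(/C=C2\SC(=O)N(Cc3cccc(F)c3)C2=O)c1` gives 690 nM
compound 3 `Cc1ccc(CN2C(=O)S/C(=C\c3cccc(N)c3)C2=O)cc1` gives only a limit, > 250000 nM

Compound 3 sits at the limit of > 250000 nM in this assay, at which 1 of the 3 values shown sits, of this assay; that value is a limit, not a number. Compound 3 differs from compound 1 by hydrogen in place of (1-bromoethenyl)carbonyl on a nitrogen on an aromatic ring, a change that gives an at least 200-fold higher number from compound 1 to compound 3 (2.31 log units; beyond the scatter). Compound 1 and compound 2 differ by 3-fluorophenyl in place of 4-methylphenyl on a saturated chain carbon bound to an amide-type nitrogen in a ring, which gives a 1.7-fold lower number from compound 1 to compound 2 (0.24 log units; within the scatter). Compound 4 `Nc1cccc(/C=C2\SC(=O)N(Cc3cccc(F)c3)C2=O)c1` is not yet measured; it differs from compound 3 by 3-fluorophenyl in place of 4-methylphenyl on a saturated chain carbon bound to an amide-type nitrogen in a ring, the same change at the same place as between compound 1 and compound 2. Compound 4 is estimated at 250000 nM, between 100000 nM and 1000000 nM, and will most likely again be reported only as a limit. That estimate means a step of a number no higher from compound 3 to compound 4 (the limit leaves the size open), expected because the matching step a 1.7-fold lower number from compound 1 to compound 2 (0.24 log units; within the scatter) lies within the scatter.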

Compound 4, half-maximal inhibitory concentration: 250000 nM
For compound 4 middle estimate and measured number coincide at the digits printed; low and high end bracket the measured number.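

Hydrogen in place of (1-bromoethenyl)carbonyl on a nitrogen on an aromatic ring gives a 360-fold higher number from compound 2 to compound 4 (2.56 log units; beyond the scatter) in this assay, so this large step appears on both cores, each carrying a different group on the saturated chain carbon: the same change on two cores in this assay, an at least 200-fold higher number (2.31 log units; beyond the scatter) from compound 1 to compound 3 and a 360-fold higher number (2.56 log units; beyond the scatter) from compound 2 to compound 4; the limit leaves it open whether they differ

The exchange of 4-methylphenyl for 3-fluorophenyl gives a number no higher from compound 3 to compound 4 (the limit leaves the size open) in this assay; the size of this step cannot be read, so it remains unknown whether the exchange carries over: the same change on two cores in this assay, a 1.7-fold lower number (0.24 log units; within the scatter) from compound 1 to compound 2 and a number no higher (the limit leaves the size open) from compound 3 to compound 4; the limit leaves it open whether they differ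

Two pairs show recurrence on these cores only, not a rule for the whole series.

Going by these compounds, it remains open whether an acetyl group or a (1-chloroethenyl)carbonyl group on that nitrogen would give numbers like those of compound 1 and compound 2. Also open, on these data alone, is how a longer chain in place of the saturated chain carbon would read.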